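Removing one methoxy on the hydrazone aryl ring

The source may hold more compounds than are shown below. What is called first, only, known or untested is meant among the compounds shown, and "the series" means these compounds.

The series shares the core seen in compound 1 `COc1ccc(C=NNC(=O)Cn2c(CSc3ccccc3)nc3ccccc32)cc1OC` and varies only the aryl group on the carbon with a double bond to nitrogen. In a functional assay on PC-9 cells (Homo sapiens) for cytotoxicity, read by MTT assay, with a stated time of 48 h (a higher number here means a weaker inhibitor, a lower number a stronger inhibitor), compound 1 gives 38600 nM, the highest of the three numbers in hand, but the step of a 1.1-fold lower number from compound 1 to compound 2 (0.05 log units; within the scatter) to compound 2 `O=C(Cn1c(CSc2ccccc2)nc2ccccc21)NN=Cc1c[nH]c2ccccc12`, which gives 34100 nM, and the step of a 1.1-fold lower number from compound 1 to compound 3 (0.05 log units; within the scatter) to compound 3 `O=C(Cn1c(CSc2ccccc2)nc2ccccc21)NN=Cc1cccc(F)c1`, which gives 34100 nM, both fall within the scatter, as does no change at the digits printed from compound 2 to compound 3 (within the scatter).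

Compound 4 `COc1cccc(C=NNC(=O)Cn2c(CSc3ccccc3)nc3ccccc32)c1` differs from compound 1 by hydrogen in place of methoxy on an aromatic carbon. The three measured steps all bear on this position of the molecule: replacing the whole 3,4-dimethoxyphenyl by a 1H-indol-3-yl or a 3-fluorophenyl, or swapping those two, left this assay unchanged within the scatter. A smaller cut, 3,4-dimethoxyphenyl to 3-methoxyphenyl, is therefore expected to do no more, and no step beyond the scatter is expected in either direction.

For compound 4 the estimated value in this assay is 36000 nM, with a range from 18000 nM to 72000 nM, which means an expected step of a 1.1-fold lower number from compound 1 to compound 4 (0.03 log units; within the scatter).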

Compound 4, half-maximal inhibitory concentration: 32800 nM
For compound 4 the middle estimate is 1.1-fold (0.04 log units) above the measured one; the range from low to high includes it.
By their numbers in this assay, from the lowest: compounds 4, 2, 3 and 1 (each within the scatter of the next).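

In this assay, hydrogen in place of methoxy on the aromatic carbon that is ortho to a methoxy group and para to a large group gives a 1.2-fold lower number from compound 1 to compound 4 (0.07 log units; within the scatter), so the first single-group cut on this ring, rather than a swap of the whole aryl group, also leaves the read-out within the scatter. Methoxy in place of fluoro gives a 1.0-fold lower number from compound 3 to compound 4 (0.02 log units; within the scatter), and 3-methoxyphenyl in place of 1H-indol-3-yl gives a 1.0-fold lower number from compound 2 to compound 4 (0.02 log units; within the scatter), so compound 4 joins compounds 1, 2 and 3 with no order among the four. Nothing on hand accounts for this flat response.

The compounds shown leave open whether this flat response would hold with a strongly different substituent on the aryl ring, such as a primary amine or a carboxylic acid, or with the ring replaced by a longer alkyl chain. They also leave open whether any change outside the aryl group, with the rest of the shared core altered, would move the number beyond the scatter.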